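Capping the Hydroxy Group of Compound 3

The source may hold more compounds than are shown below. What is called first, only, known or untested is meant among the compounds shown, and "the series" means these compounds.

Of the compounds shown here, three sharing one core have been measured in a functional assay (trachea) with Rattus norvegicus as the target; on this read-out higher numbers stand for higher potency (the scale is a negative logarithm) and lower numbers for lower potency. Compound 1 `CCC(=O)c1ccc2c(c1)C(n1ccccc1=O)=CC(C)(C)O2` gives 5.85, compound 2 `CC1(C)C=C(n2ccccc2=O)c2cc(C=O)ccc2O1` gives 6.14, and compound 3 `CC1(C)C=C(n2ccccc2=O)c2cc(O)ccc2O1` gives 5.31, the lowest of the three. Compound 4 `CC1(C)C=C(n2ccccc2=O)c2cc(OC(=O)Nc3ccccc3F)ccc2O1` has not been measured; it differs from compound 3 by (2-fluorophenyl)carbamoyl in place of hydrogen on an oxygen on an aromatic ring. Going by the values given here, two measured steps bear on this. One is a number 0.54 log units lower from compound 1 to compound 3 (beyond the scatter), and another is a number 0.83 log units lower from compound 2 to compound 3 (beyond the scatter); both times compound 3, with the free hydroxy, stands lower than a partner carrying a carbonyl-bearing group. Compound 4 again carries a carbonyl-bearing group, so a modest rise is expected, a number 0.69 log units higher from compound 3 to compound 4 (beyond the scatter). Compound 4 is therefore estimated at 6, within 5.3 to 6.7.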

Compound 4, logarithm of the reciprocal of the active concentration, log(1/C): 4.22
For compound 4 the middle estimate is 1.78 log units above the measured one; measured number below the stated range.
By their numbers in this assay, from the lowest: compound 4; then compound 3; then compounds 1 and 2 (each within the scatter of the next).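

In this assay, putting (2-fluorophenyl)carbamoyl on the oxygen gives a number 1.09 log units lower from compound 3 to compound 4 (beyond the scatter). Earlier, the free hydroxy compound stood lower than its partners with a carbonyl-bearing group, but this step shows that a carbonyl in the new group does not by itself bring a higher number, and that capping this oxygen can lower it. Nothing available here explains the drop. Still open, on these data alone, is how a smaller cap on the same oxygen, such as methyl or acetyl, would compare with compound 3, and whether plain phenylcarbamoyl, without the fluorine, would behave like compound 4.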